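Five-membered ring swaps on the chain carbon

A few compounds are considered here, and "the series" means these few. Any claim that something is new, unique, unknown or untested is made for them only; others in the source may bear on it.

The series shares one core and varies the five-membered aromatic ring on the saturated chain carbon bound to a nitrogen on an aromatic ring and a saturated chain carbon. Compound 1 `CC[C@@H](Nc1c(Nc2cccc(C(=O)N(C)C)c2O)c(=O)c1=O)c1ccc(C)s1` carries 5-methylthiophen-2-yl there; in an assay on CHO cells for displacement of a labelled ligand from C-X-C chemokine receptor type 1 (Homo sapiens) (on this read-out lower numbers stand for stronger inhibition and higher numbers for weaker inhibition), compound 1 gives 146 nM, the highest number of the three measured, with compound 2 nearest and compound 3 furthest. Compound 2 `CC[C@@H](Nc1c(Nc2cccc(C(=O)N(C)C)c2O)c(=O)c1=O)c1cc(C)cs1` gives 24 nM in this assay, and compound 3 `CC[C@@H](Nc1c(Nc2cccc(C(=O)N(C)C)c2O)c(=O)c1=O)c1cc(C)co1` gives 9 nM. The measured steps are a 6.1-fold lower number from compound 1 to compound 2 (0.78 log units; beyond the scatter), a 16-fold lower number from compound 1 to compound 3 (1.21 log units; beyond the scatter) and a 2.7-fold lower number from compound 2 to compound 3 (0.43 log units; beyond the scatter).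

Compound 4 `CC[C@@H](Nc1c(Nc2cccc(C(=O)N(C)C)c2O)c(=O)c1=O)c1cc(C(C)(C)C)co1` differs from compound 1 as follows: 4-(tert-butyl)furan-2-yl in place of 5-methylthiophen-2-yl on a saturated chain carbon bound to a nitrogen on an aromatic ring and a saturated chain carbon. The step that bears most directly is a 16-fold lower number from compound 1 to compound 3 (1.21 log units; beyond the scatter), since compound 3 also carries a furan, 4-methylfuran-2-yl; the steps of a 6.1-fold lower number from compound 1 to compound 2 (0.78 log units; beyond the scatter) and a 2.7-fold lower number from compound 2 to compound 3 (0.43 log units; beyond the scatter) point the same way. Among the compounds with values here, no measured pair shows a tert-butyl in place of a methyl, so the size of that part of the change is unknown. A lower number than for compound 1 is therefore expected in this assay, estimated as a 7.3-fold lower number from compound 1 to compound 4 (0.86 log units; beyond the scatter). For compound 4 the estimated value is 20 nM, with a range from 5 nM to 80 nM.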

Compound 4, inhibition constant: 10 nM
For compound 4 the middle estimate is 2.0-fold (0.30 log units) above the measured one; measured number inside the range.
By their numbers in this assay, from the lowest: compounds 3 and 4 (each within the scatter of the next); then compound 2; then compound 1.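

Tert-butyl in place of methyl on an aromatic carbon gives a 1.1-fold higher number from compound 3 to compound 4 (0.05 log units; within the scatter), so this furan position accepts the added bulk of 4-(tert-butyl)furan-2-yl with no read-out difference beyond the scatter. The larger group also keeps the advantage over the thiophens, with a 15-fold lower number from compound 1 to compound 4 (1.16 log units; beyond the scatter) and a 2.4-fold lower number from compound 2 to compound 4 (0.38 log units; beyond the scatter), so both furans now sit below both thiophens in this small set, and no compound shown goes against that. Nothing shown gives a reason for these results.

A 4-(tert-butyl)thiophen-2-yl group would test whether the tert-butyl result holds with sulfur in the ring, since the thiophen pair so far carries only methyl. On these data alone, whether this position also accepts an amine or a carboxylic acid in place of the tert-butyl remains open.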